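Swapping tert-butyl for thiophen-3-yl on a shared core

The source may hold more compounds than are shown below. What is called first, only, known or untested is meant among the compounds shown, and "the series" means these compounds.

Three measured compounds share one core and differ in a single group. In a functional assay on Jurkat cells for inhibition of nuclear factor NF-kappa-B complex (Homo sapiens) (a lower number here means a stronger inhibitor, a higher number a weaker inhibitor), compound 1 `CCOC(=O)c1cnc(C)nc1NN1C(=O)C=C(C)C1=O` gives 16000 nM, compound 2 `CCOC(=O)c1cnc(C(C)(C)C)nc1NN1C(=O)C=C(C)C1=O` gives 1000 nM, and compound 3 `CCOC(=O)c1cnc(-c2ccncc2)nc1NN1C(=O)C=C(C)C1=O` gives 6000 nM. Compound 2 has the lowest number of the three: the step of a 16-fold lower number from compound 1 to compound 2 (1.20 log units; beyond the scatter) is large, and a 6.0-fold higher number from compound 2 to compound 3 (0.78 log units; beyond the scatter) also lies beyond the scatter. Compound 4 `CCOC(=O)c1cnc(-c2ccsc2)nc1NN1C(=O)C=C(C)C1=O` changes compound 2 in one place: thiophen-3-yl in place of tert-butyl on an aromatic carbon. The step of a 6.0-fold higher number from compound 2 to compound 3 (0.78 log units; beyond the scatter), where an aromatic ring replaced tert-butyl, is the one that bears on this change, while a 2.7-fold lower number from compound 1 to compound 3 (0.43 log units; beyond the scatter) shows that ring still ahead of methyl. A modest rise in this assay is therefore expected, a 2.5-fold higher number from compound 2 to compound 4 (0.40 log units; beyond the scatter). Compound 4 is estimated at 2500 nM, within 800 nM to 8000 nM.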

Compound 4, half-maximal inhibitory concentration: 100 nM
Compound 4: middle estimate off by 25-fold (1.40 log units), on the high side; measured number outside the range, below it.
By their numbers in this assay, from the lowest: compound 4; then compound 2; then compound 3; then compound 1.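

On the aromatic carbon between two ring nitrogen atoms, an aromatic ring can outdo tert-butyl, as a 10-fold lower number from compound 2 to compound 4 (1.00 log units; beyond the scatter) in this assay shows, so compound 3 does not stand for every ring. The identity of the ring matters greatly, given a 60-fold lower number from compound 3 to compound 4 (1.78 log units; beyond the scatter) between the two rings, and the gain over the smallest group reaches a 160-fold lower number from compound 1 to compound 4 (2.20 log units; beyond the scatter) in this series. No supporting data are available to explain this result.

Whether the gain is particular to thiophen-3-yl remains open, since the compounds shown do not include thiophen-2-yl or phenyl. How an amine at this position would compare is also unknown.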